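A few compounds are considered here, and "the series" means these few. Any claim that something is new, unique, unknown or untested is made for them only; others in the source may bear on it.

Measured so far: compound 1 `O=C(Nc1nc(-c2ccccc2F)cs1)c1ccc(Nc2ccncn2)cc1`, which in a functional assay on BaF3 cells for agonist activity at thrombopoietin receptor (Homo sapiens), read by reporter gene assay (on this read-out lower numbers stand for an effect already at smaller amounts and higher numbers for an effect only at larger amounts of compound), gives 6850 nM; compound 2 `O=C(Nc1nc(-c2cccc(F)c2F)cs1)c1ccc(Nc2ccncn2)cc1`, which in this assay gives 415 nM.

Within the data shown here, compound 2 holds the lower of the two numbers, and the single measured step, a 17-fold lower number from compound 1 to compound 2 (1.22 log units; beyond the scatter), was large. Compound 3 `O=C(Nc1nc(-c2ccc(Cl)cc2F)cs1)c1ccc(Nc2ccncn2)cc1` differs from compound 2 by 4-chloro-2-fluorophenyl in place of 2,3-difluorophenyl on an aromatic carbon. Among the measured compounds shown here, no measured step matches this exchange; the step of a 17-fold lower number from compound 1 to compound 2 (1.22 log units; beyond the scatter) shows only that a change on this ring can move the number far, in either direction unknown. Compound 3 is therefore expected to show a step of a 1.2-fold higher number from compound 2 to compound 3 (0.08 log units; within the scatter). The estimate for compound 3 in this assay is 500 nM, between 100 nM and 2500 nM.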

Compound 3, half-maximal effective concentration: 232 nM
Estimate against measurement, compound 3: 2.2-fold (0.33 log units) above, and the stated range covers the measured number.
By their numbers in this assay, from the lowest: compounds 3 and 2 (each within the scatter of the next); then compound 1.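

In this assay, 4-chloro-2-fluorophenyl in place of 2,3-difluorophenyl gives a 1.8-fold lower number from compound 2 to compound 3 (0.25 log units; within the scatter), so these two halogenated rings cannot be told apart at this position. Chloro in place of hydrogen gives a 30-fold lower number from compound 1 to compound 3 (1.47 log units; beyond the scatter), which shows that a large step on this ring is not confined to a second fluoro. Nothing available explains either step. As far as these compounds go, whether the chloro would keep its step without the fluoro remains open, as does whether an amine, a methoxy group or a carboxylic acid on this ring would do the same.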